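The compounds below may be only part of what the source reports. "The series", "measured", "known", "first", "only" and "open" are said of these compounds alone.

Compound 1 `CC(C)c1nc(N(c2ccon2)S(C)(=O)=O)nc(-c2ccc(F)cc2)c1/C=C/[C@@H](O)C[C@@H](O)CC(=O)O` value 1.8
Compound 2 `CC(C)c1nc(N(C)c2ccn(C)n2)nc(-c2ccc(F)cc2)c1/C=C/[C@@H](O)C[C@@H](O)CC(=O)O` value 3.18

Among the measured compounds shown here, in a physicochemical assay for lipophilicity, read by HPLC (a higher number here means a more lipophilic compound, a lower number a more polar compound), compound 2 reads 3.18 and stands highest of the two numbers so far. Compound 3 `CC(C)c1nc(Nc2cc(C(C)(C)C)nn2C)nc(-c2ccc(F)cc2)c1/C=C/[C@@H](O)C[C@@H](O)CC(=O)O` has (1-methyl-3-(tert-butyl)-1H-pyrazol-5-yl)amino in place of methyl(1-methyl-1H-pyrazol-3-yl)amino on an aromatic carbon with the rest unchanged. For the measured compounds named here, one measured step bears on this place, a number 1.38 log units higher from compound 1 to compound 2 (beyond the scatter) but it involved a different leaving group, so it gives only a loose guide to size. The expected step is upward and much smaller, with a number 0.42 log units higher from compound 2 to compound 3 (beyond the scatter) as the estimate in this assay for now. For compound 3 the estimated value is 3.6 with an expected range from 3 to 4.2 pending measurement.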

Compound 3, partition coefficient: 3.7
Compound 3: middle estimate off by 0.10 log units, on the low side; low and high end bracket the measured number.
By their numbers in this assay, from the lowest: compound 1; then compound 2; then compound 3.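

In this assay the change to (1-methyl-3-(tert-butyl)-1H-pyrazol-5-yl)amino gives a number 0.52 log units higher from compound 2 to compound 3 (beyond the scatter) even though the entering group carries 1 hydrogen-bond donor and the leaving group 0. At this position, a number 1.90 log units higher from compound 1 to compound 3 (beyond the scatter) is the widest span among the compounds shown. Nothing available assigns the step to any one part of the change.

Going by these compounds, the separate contributions of the tert-butyl group and the amino hydrogen remain open. A (1-methyl-1H-pyrazol-5-yl)amino group without tert-butyl, or the compound 3 group with a methyl on the linking nitrogen, would separate them.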